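Dropping the methoxy from the benzyl group of compound 2

The compounds below may be only part of what the source reports. "The series", "measured", "known", "first", "only" and "open" are said of these compounds alone.

In an ADME assay on Vero cells (Chlorocebus sabaeus) for cytotoxicity, with a stated time of 7 days (on this read-out higher numbers stand for lower toxicity in this test and lower numbers for higher toxicity in this test), compound 1 `COc1ccc2[nH]c(C(=O)N3CC(=O)N(Cc4ccccc4)[C@@H](CN4CCCCC4)C3)cc2c1` gives 76900 nM. Compound 2 `COc1cccc(CN2C(=O)CN(C(=O)c3cc4cc(OC)ccc4[nH]3)C[C@@H]2Cc2ccccn2)c1` is known in this assay only as a limit, > 10000 nM, and not as a number. Compound 2 thus stands at the limit of > 10000 nM in this assay, at which 1 of the 2 values shown sits. Compound 3 `COc1ccc2[nH]c(C(=O)N3CC(=O)N(Cc4ccccc4)[C@@H](Cc4ccccn4)C3)cc2c1` differs from compound 2 by hydrogen in place of methoxy on an aromatic carbon. Going by the values given here, no measured pair of compounds covers this change, so the step in this assay is expected to be small, none beyond the usual scatter in either direction, as in a step that the limit leaves unreadable from compound 2 to compound 3. Compound 3 is therefore estimated at 50000 nM, between 15000 nM and 150000 nM.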

Compound 3, half-maximal cytotoxic concentration: > 30000 nM
Compound 3 was reported as a limit; the forecaster's own chance of this, stated with the estimate: 50%; the middle value is on the limit's open side.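

Going by these compounds alone, compound 3 stands only as a limit, > 30000 nM, so no step linking it to compound 1 or compound 2 can be read. Going by these compounds, how far either hydrogen in place of methoxy or pyridin-2-yl in place of piperidin-1-yl shifts the half-maximal cytotoxic concentration remains open.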